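This account rests on a few compounds, and the source may have more. Where it says the series, first, only, none or still open, it means among the compounds named here.

Among the measured compounds shown here, compound 3 `C#Cc1cccc(N2C(=O)CSC2c2cccc(C(=O)NCCCCc3ccccc3)c2)c1` is the only compound here that gives a number in a functional assay on HOS-TE85 cells (Homo sapiens) for inhibition, read by CCK-8 assay, with a stated time of 72 h; on this read-out higher numbers stand for weaker inhibition and lower numbers for stronger inhibition; compound 3 gives 149 nM. Compound 1 `CC(C)(C)c1conc1N1C(=O)CSC1c1cccc(C(=O)NCCCCc2ccccc2)c1` returns only a limit in this assay, > 1000 nM. Compound 2 `COc1ccc(OC)c(N2C(=O)CSC2c2cccc(C(=O)NCCCCc3ccccc3)c2)c1` likewise returns only a limit, > 1000 nM. Compound 4 `O=C(NCCCCc1ccccc1)c1cccc(C2SCC(=O)N2c2nccs2)c1` differs from compound 3 by 1,3-thiazol-2-yl in place of 3-ethynylphenyl on an amide-type nitrogen in a ring. The measured steps that bear on this run the other way: an at least 6.7-fold lower number from compound 1 to compound 3 (0.82 log units; beyond the scatter) and an at least 6.7-fold lower number from compound 2 to compound 3 (0.82 log units; beyond the scatter), each starting from a limit, so only a floor on their size is known. Because an at least 6.7-fold lower number from compound 1 to compound 3 (0.82 log units; beyond the scatter) went toward stronger inhibition when a five-membered aromatic ring with 2 hetero atoms gave way to a six-membered aromatic ring of carbon only, compound 4 is expected to show a 6.7-fold higher number from compound 3 to compound 4 (0.83 log units; beyond the scatter). Compound 4 is therefore estimated at 1000 nM, with a range from 300 nM to 3000 nM.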

Compound 4, half-maximal inhibitory concentration: > 1000 nM
Compound 4 ended at the assay's limit; the forecaster's own chance of this, stated with the estimate: 50%; the middle value sits exactly at the limit.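

The change from 3-ethynylphenyl to 1,3-thiazol-2-yl on the amide-type nitrogen in a ring gives an at least 6.7-fold higher number from compound 3 to compound 4 (0.82 log units; beyond the scatter). A smaller five-membered aromatic ring with 2 hetero atoms thus fares no better here than the larger group of compound 1, though compound 2, with its six-membered aromatic ring, goes against any rule based on ring size alone. The steps among compounds 1, 2 and 4 cannot be read, and only compound 3 stands clear of the limit: the limit of > 1000 nM in this assay, at which 3 of the 4 values shown sit.

Going by these compounds, what a plain phenyl or a 3-cyanophenyl would give at this position stays open. So does whether the triple bond of compound 3 matters in itself.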